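A few compounds are considered here, and "the series" means these few. Any claim that something is new, unique, unknown or untested is made for them only; others in the source may bear on it.

Compound 1, with the structure `C/C=C(\C)[C@H]1OC(=O)[C@@H](C)NC(=O)[C@H]([C@@H](C)CC)NC(=O)CN(C)C(=O)[C@@H](Cc2ccccc2)N(C)C(=O)[C@H](C)NC(=O)[C@@H](CC(C)C)OC(=O)/C(C)=C/C[C@H](O)[C@@H]1C`, is the most potent of the two compounds measured here: in a functional assay on MCF7 cells (Homo sapiens) for cytotoxicity, read by CellTiter-Blue, with a stated time of 72 h (on this read-out higher numbers stand for weaker inhibition and lower numbers for stronger inhibition), compound 1 gives 0.22 nM, the lowest number of the two. Among the measured compounds shown here, its only measured neighbour is compound 2, `C/C=C(\C)[C@H]1OC(=O)[C@@H](C)NC(=O)[C@H]([C@@H](C)CC)NC(=O)CN(C)C(=O)[C@@H](Cc2ccccc2)N(C)C(=O)[C@H](C)NC(=O)[C@@H](CC(C)C)OC(=O)/C(C)=C/C[C@H](OCSC)[C@@H]1C`, which in this assay gives 6.3 nM; the step of a 29-fold higher number from compound 1 to compound 2 (1.46 log units; beyond the scatter) is well beyond the scatter and comes from placing a (methylsulfanyl)methyl in place of hydrogen on an oxygen on a saturated carbon.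

Compound 3, `C/C=C(\C)[C@H]1OC(=O)[C@@H](C)NC(=O)[C@H]([C@@H](C)CC)NC(=O)CN(C)C(=O)[C@@H](Cc2ccccc2)N(C)C(=O)[C@@H](C)NC(=O)[C@@H](CC(C)C)OC(=O)/C(C)=C/C[C@H](O)[C@@H]1C`, is the next compound to be measured. It differs from compound 1 as follows: the two compounds have the same atoms and bonds and differ only in configuration as drawn: 1 of 11 stereo elements differ; a stereocentre at a saturated ring carbon is drawn S in compound 1 and R in compound 3. No measured step bears on this kind of change: the one step shown alters a group on an oxygen and leaves every stereocentre untouched, so it offers no guide to the effect of inverting a ring stereocentre. The direction and size of the step in this assay therefore rest on no shown datum, and a wide range is the honest answer.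

Compound 3 is expected to give about 5 nM in this assay, within 0.2 nM to 150 nM. The expected step of a 23-fold higher number from compound 1 to compound 3 (1.36 log units; beyond the scatter) is thus an estimate of a weaker inhibitor than compound 1.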

Compound 3, half-maximal inhibitory concentration: 1650 nM
Estimate against measurement, compound 3: 330-fold (2.52 log units) below; measured number above the stated range.
By their numbers in this assay, from the lowest: compound 1; then compound 2; then compound 3.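

The step of a 7500-fold higher number from compound 1 to compound 3 (3.88 log units; beyond the scatter) in this assay shows that this read-out is highly sensitive to the configuration of the core, something compounds 1 and 2 could not reveal because they share every stereocentre. The earlier step, a 29-fold higher number from compound 1 to compound 2 (1.46 log units; beyond the scatter), showed that compound 1 loses potency when a (methylsulfanyl)methyl replaces the hydrogen on an oxygen, yet that change costs far less than inverting one saturated ring carbon. The loss can be assigned to that inverted stereocentre alone, with no substituent entering or leaving, because of this: the fact that compounds 1 and 3 differ only in the configuration as drawn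

The compounds shown leave open whether the other stereocentres of the core are as demanding as this one, and whether the (methylsulfanyl)methyl would cost as much on the inverted form of compound 3 as it does on compound 1. They also leave open how an acetyl group, a longer alkyl chain or a chain carrying an amine would compare with the (methylsulfanyl)methyl on that oxygen, so the tolerance of that position remains defined by a single substituent.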